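The compounds below may be only part of what the source reports. "The series", "measured", "known", "first", "only" and "open" are said of these compounds alone.

Measured in a functional assay on NSCLC cells (Homo sapiens) for inhibition; on this read-out higher numbers stand for weaker inhibition of growth and lower numbers for stronger inhibition of growth:
- compound 1 `Cc1ccnc2nc(-c3cccc(Cl)c3)cc(O)c12`: 100000 nM
- compound 2 `Cc1cc(C)c2c(O)cc(-c3cccc(F)c3)nc2n1`: 2510 nM
- compound 3 `Cc1cnc2[nH]c(-c3cccc(Cl)c3)cc(=O)c2c1`: 44700 nM

Compound 1 stands highest of the three, so it is the weakest inhibitor of growth in this set. Compound 3 lies nearest below it and compound 2 furthest, both beyond the scatter.

The next compound to be measured is compound 4 `Oc1cc(-c2cccc(Cl)c2)nc2ncccc12`, which differs from compound 1 by hydrogen in place of methyl on an aromatic carbon. Within the data shown here, no measured pair isolates this change, so the data give no direct size for it. Only the overall spread is available, with compound 3 at 44700 nM and compound 2 at 2510 nM. A small move in this assay towards a lower number is expected, and it may not exceed the scatter. The expected step is a 2.0-fold lower number from compound 1 to compound 4 (0.30 log units; within the scatter). Compound 4 is estimated at 50000 nM, with an expected range of 15000 nM to 100000 nM.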

Compound 4, concentration for total growth inhibition: 85100 nM
The estimate for compound 4 lay 1.7-fold (0.23 log units) below the measured number; measured number inside the range.
By their numbers in this assay, from the lowest: compound 2; then compounds 3, 4 and 1 (each within the scatter of the next, the first and the last beyond it).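

In this assay, hydrogen in place of methyl on this aromatic carbon, opposite the ring nitrogen, reads as a 1.2-fold lower number from compound 1 to compound 4 (0.07 log units; within the scatter) and cannot be told apart from no change. Among these compounds, this is the first pair to isolate a single change, and it gives this position a direct size for the swap, which the earlier compounds could not. On the core of compound 1, the methyl here therefore makes no readable difference to growth inhibition, and nothing at hand accounts for that result.

Only hydrogen and methyl are shown at this carbon, so the effect of a longer chain, a methoxy group or an amine there remains open. Whether the same swap would also stay within the scatter on a core with other substituents is equally unsettled.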